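Replacing the 4-cyanobenzyl of compound 3 with an allyl group

The source may report more compounds than this note shows. Statements on the series, on what has been measured and on what is new or still open speak of the compounds shown alone.

Measured compounds:
compound 1, `COc1ccc(N(Cc2ccccc2)NC(=O)NCCCN2CCN(c3ccccc3OC)CC2)cc1`, 1.7 nM
compound 2, `COc1ccc(N(Cc2ccccc2F)NC(=O)NCCCN2CCN(c3ccccc3OC)CC2)cc1`, 2.6 nM
compound 3, `COc1ccc(N(Cc2ccc(C#N)cc2)NC(=O)NCCCN2CCN(c3ccccc3OC)CC2)cc1`, 16 nM

All three share one core and differ only in the group carried on the saturated chain carbon bound to a nitrogen on an aromatic ring. In an assay on CHO cells for displacement of a labelled ligand from D(4) dopamine receptor (Homo sapiens), read by radioligand binding (on this read-out lower numbers stand for stronger inhibition and higher numbers for weaker inhibition), compound 3 gives the highest of the three numbers: one step is a 6.2-fold higher number from compound 2 to compound 3 (0.79 log units; beyond the scatter) and the other is a 9.4-fold higher number from compound 1 to compound 3 (0.97 log units; beyond the scatter), both beyond the scatter, while compound 1 and compound 2 differ only by a 1.5-fold higher number from compound 1 to compound 2 (0.18 log units; within the scatter), within the scatter.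

Compound 4, `C=CCN(NC(=O)NCCCN1CCN(c2ccccc2OC)CC1)c1ccc(OC)cc1`, has not been measured in this assay. Its change from compound 3 is vinyl in place of 4-cyanophenyl on a saturated chain carbon bound to a nitrogen on an aromatic ring. For the measured compounds named here, none of the measured steps tests removal of the aromatic ring itself; the two steps to compound 3 only show that the group on this chain carbon can move the number by a modest amount. A step of roughly that size, in either direction, is therefore the expectation, with the direction uncertain because compound 3 already carries the weakest number.

Compound 4 is expected to give 30 nM, in a range from 8 nM to 120 nM, an estimated step of a 1.9-fold higher number from compound 3 to compound 4 (0.27 log units; within the scatter).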

Compound 4, inhibition constant: 61 nM
Compound 4: middle estimate off by 2.0-fold (0.31 log units), on the low side; low and high end bracket the measured number.
By their numbers in this assay, from the lowest: compounds 1 and 2 (each within the scatter of the next); then compound 3; then compound 4.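

In this assay, compound 4 carries the only group shown at this place without an aromatic ring, and it gives the highest number of the four, with a 3.8-fold higher number from compound 3 to compound 4 (0.58 log units; beyond the scatter) and also a 23-fold higher number from compound 2 to compound 4 (1.37 log units; beyond the scatter) and a 36-fold higher number from compound 1 to compound 4 (1.55 log units; beyond the scatter) as its steps. For the compounds shown here, the earlier compounds showed only that changes on the aromatic ring of a benzyl group could raise the number or leave it within the scatter, whereas this change shows that replacing benzyl-type groups with allyl raises it further, by a modest step from the 4-cyanobenzyl of compound 3 and by large steps from the other two. Nothing among the data shown explains this rise.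

Going by these compounds, whether a saturated propyl chain, a longer chain or a cyclohexylmethyl group at this place would give numbers closer to those of compound 4 or to those of the benzyl compounds remains open. Also open, on these data alone, is whether the higher number of compound 3 belongs to the nitrile itself or to where it sits on the ring, a question that a 2-cyanobenzyl or 3-cyanobenzyl group would address.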